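This account rests on a few compounds, and the source may have more. Where it says the series, first, only, none or still open, it means among the compounds named here.

Series notes. Compound 2 `CCc1cc(C(C)=O)c(O)cc1OCCCC(C)(C)C(=O)O` gives 12% in an assay on isolated protein for binding affinity to leukotriene B4 receptor (Homo sapiens), tested at 0.1 uM; on this read-out lower numbers stand for less inhibition and higher numbers for more inhibition at the one concentration tested (going by the name of the read-out). Compound 1 `CCc1cc(C(C)=O)c(O)cc1OCCCCC(C)(C)C#N` gives 5% in this assay, and a number 7 percentage points higher from compound 1 to compound 2 (within the scatter), so the two stand together within the scatter. Compound 3 `CCc1cc(C(C)=O)c(O)cc1OCCCCCC(C)(C)C(=O)O` carries 3-carboxy-3-methylbutyl in place of 1-carboxy-1-methylethyl on a saturated chain carbon, three bonds along the chain from an oxygen on an aromatic ring. Within the data shown here, no measured step alters the chain length. Among the measured compounds shown here, the single step, from compound 1 to compound 2, exchanges the terminal group at equal length and stays within the scatter. No step beyond the scatter is therefore expected, and no change at the digits printed from compound 2 to compound 3 (within the scatter) is the estimated change. Compound 3 is expected to give 12%, within 0% to 30%.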

Compound 3, a percentage reported as inhibition, at one concentration (the size of the read-out at that concentration, not a potency): 20%
Compound 3: the middle estimate sits 8 percentage points below what was measured, within the range that was stated.
By their numbers in this assay, from the lowest: compounds 1, 2 and 3 (each within the scatter of the next, the first and the last beyond it).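

In this assay the change to 3-carboxy-3-methylbutyl from 1-carboxy-1-methylethyl gives a number 8 percentage points higher from compound 2 to compound 3 (within the scatter) and so leaves the effect of this chain change unresolved. Among these compounds, the only step beyond the scatter is a number 15 percentage points higher from compound 1 to compound 3 (beyond the scatter) and replaces 1-cyano-1-methylethyl with 2-carboxy-2-methylpropyl, so the nitrile-to-carboxylic-acid exchange and the difference in chain length cannot be separated. No supporting measurement explains these differences. From the compounds shown here alone, what a primary amide at the chain end or a still longer chain would give remains open.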